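Trading an Octyl Chain for 3-Phenoxypropyl

The source may hold more compounds than are shown below. What is called first, only, known or untested is meant among the compounds shown, and "the series" means these compounds.

In a functional assay on PC-3 cells (Homo sapiens) for antiproliferative activity, read by MTT assay, with a stated time of 48 h (on this read-out higher numbers stand for weaker inhibition of growth and lower numbers for stronger inhibition of growth), compound 1 `CCCCCCCCN(Cc1ccc(C(=O)NO)cc1)c1ncc(-c2ccc(C)cc2)s1` gives 13300 nM, within the scatter of compound 2 `Cc1ccc(-c2cnc(N(CCCCOc3ccccc3)Cc3ccc(C(=O)NO)cc3)s2)cc1` at 10300 nM, while compound 3 `CCCCCCN(Cc1ccc(C(=O)NO)cc1)c1ncc(-c2ccc(C)cc2)s1` gives 5270 nM. Compound 4 `Cc1ccc(-c2cnc(N(CCCOc3ccccc3)Cc3ccc(C(=O)NO)cc3)s2)cc1` differs from compound 1 by phenoxy in place of pentyl on a saturated chain carbon, three bonds along the chain from a nitrogen on an aromatic ring, or octyl to 3-phenoxypropyl. Among the measured compounds shown here, two measured steps bear on this: the phenoxy-ended chain, a 1.3-fold lower number from compound 1 to compound 2 (0.11 log units; within the scatter), and the hexyl chain, a 2.5-fold lower number from compound 1 to compound 3 (0.40 log units; beyond the scatter). Together they suggest a small move towards a lower number, possibly not beyond the scatter. The expected step is a 1.8-fold lower number from compound 1 to compound 4 (0.25 log units; within the scatter). For compound 4 the estimated value is 7500 nM, with an expected range of 3800 nM to 14000 nM.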

Compound 4, concentration for 50% growth inhibition: 17500 nM
Beside the measured number, compound 4's estimate is 2.3-fold (0.37 log units) below it; measured number above the stated range.
By their numbers in this assay, from the lowest: compounds 3, 2, 1 and 4 (each within the scatter of the next, the first and the last beyond it).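

In this assay the change from octyl to 3-phenoxypropyl does not separate the two compounds (a 1.3-fold higher number from compound 1 to compound 4 (0.12 log units; within the scatter)), and neither does phenoxy in place of phenoxymethyl (a 1.7-fold higher number from compound 2 to compound 4 (0.23 log units; within the scatter)). Phenoxy in place of propyl does separate them (a 3.3-fold higher number from compound 3 to compound 4 (0.52 log units; beyond the scatter)), so compound 4 parts from the hexyl chain of compound 3, which compound 2 did not.

From the compounds shown here alone, whether an amine or a carboxylic acid in place of the phenoxy end would move the number beyond the scatter stays open. Nothing measured here explains these numbers.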